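The compounds below may be only part of what the source reports. "The series", "measured", "known", "first", "only" and "open" are said of these compounds alone.

Measured in a functional assay on MCF7 cells (Homo sapiens) for antiproliferative activity, read by MTT assay, with a stated time of 24 h; a lower number here means a stronger inhibitor, a higher number a weaker inhibitor:
- Compound 1 `CCn1c(C(=O)N[C@@H](C)C(=O)O)ccc1C(CC)(CC)c1ccc(OCS(=O)(=O)c2ccccc2)c(C)c1`: 35500 nM
- Compound 2 `CCn1c(C(=O)N[C@H](C)C(=O)O)ccc1C(CC)(CC)c1ccc(OCS(=O)(=O)c2ccccc2)c(C)c1`: > 50000 nM

For compound 2, the assay gives only a limit, > 50000 nM. Its position therefore has no upper bound on these numbers. Compound 3 `CCn1c(C(=O)N[C@H](C(=O)O)C(C)C)ccc1C(CC)(CC)c1ccc(OCS(=O)(=O)c2ccccc2)c(C)c1` carries one structural change: 1-carboxy-2-methylpropyl in place of 1-carboxyethyl on an amide-type nitrogen.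

Within the data shown here, the one measured step is an at least 1.4-fold higher number from compound 1 to compound 2 (0.14 log units; that floor lies within the scatter). It reflects (the fact that compounds 1 and 2 differ only in the configuration as drawn), so it does not size a change of this group. Among the measured compounds shown here, with no measured step for this change, the expectation rests on the level of the pair, with compound 1 at 35500 nM. No step beyond the scatter is expected, and no direction can be favoured. Compound 3 could also return only a limit.

Compound 3 is estimated at 45000 nM, with an expected range of 18000 nM to 100000 nM. The expected change is an at least 1.1-fold lower number from compound 2 to compound 3 (0.04 log units; that floor lies within the scatter).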

Compound 3, half-maximal inhibitory concentration: 24500 nM
Estimate against measurement, compound 3: 1.8-fold (0.26 log units) above, and the stated range covers the measured number.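

The change of the group itself can now be read at this position: isopropyl in place of methyl on the saturated chain carbon bound to an amide-type nitrogen and a carbonyl carbon gives a 1.4-fold lower number from compound 1 to compound 3 (0.16 log units; within the scatter) in this assay, so this change leaves compound 3 level with compound 1. The other step, an at least 2.0-fold lower number from compound 2 to compound 3 (0.30 log units; that floor lies within the scatter), is only a floor because it starts from a limit: the limit of > 50000 nM in this assay, at which 1 of the 3 values shown sits. Compound 2 remains a limit at > 50000 nM.

As far as these compounds go, whether a longer chain, a phenyl ring or an amine on this carbon would move the number beyond the scatter stays open. Among these compounds, also open is whether configuration at this carbon matters at all, since the one pair differing there reaches only a limit.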